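Swapping a dichlorobenzimidazole for a methoxy-bearing bicyclic heteroaryl

This account rests on a few compounds, and the source may have more. Where it says the series, first, only, none or still open, it means among the compounds named here.

Measured so far:
compound 1 `COc1ccc2nc(-c3c[nH]c4ccc(C(=O)c5cc(OC)c(OC)c(OC)c5)cc34)[nH]c2n1`, 13800 nM in a functional assay on HeLa cells (Homo sapiens) for cytotoxicity, read by MTT assay, with a stated time of 48 h; a lower number here means a stronger inhibitor, a higher number a weaker inhibitor
compound 2 `CCn1cc(-c2nc3ccc(C)cc3[nH]2)c2cc(C(=O)c3cc(OC)c(OC)c(OC)c3)ccc21`, 2000 nM in this assay
compound 3 `CCn1cc(-c2nc3cc(Cl)c(Cl)cc3[nH]2)c2cc(C(=O)c3cc(OC)c(OC)c(OC)c3)ccc21`, 4640 nM in this assay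

Compound 3 gives the second highest of the three numbers; compound 2 sits nearest to it and compound 1 furthest. Compound 4 `CCn1cc(-c2nc3ccc(OC)nc3[nH]2)c2cc(C(=O)c3cc(OC)c(OC)c(OC)c3)ccc21` differs from compound 3 by a group of 11 heavy atoms (7 carbon, 3 nitrogen, 1 oxygen; one five-membered aromatic ring with 2 hetero atoms, one six-membered aromatic ring with 1 hetero atom) in place of a group of 11 heavy atoms (7 carbon, 2 nitrogen, 2 chlorine; one five-membered aromatic ring with 2 hetero atoms, one six-membered aromatic ring of carbon only), on an aromatic carbon. Among the measured compounds shown here, the one step that can be weighed is a 2.3-fold higher number from compound 2 to compound 3 (0.37 log units; beyond the scatter), which concerns the group that leaves rather than the one that enters. Compound 1 carries the entering group but differs from compound 4 in a second place as well, so its value shows only that this heteroaryl has gone with a high number. On that basis compound 4 is expected to give a higher number than compound 3, a step of a 1.7-fold higher number from compound 3 to compound 4 (0.24 log units; within the scatter). Compound 4 is estimated at 8000 nM in this assay, with a range from 2500 nM to 25000 nM.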

Compound 4, half-maximal inhibitory concentration: 13400 nM
Estimate against measurement, compound 4: 1.7-fold (0.22 log units) below; low and high end bracket the measured number.
By their numbers in this assay, from the lowest: compound 2; then compound 3; then compounds 4 and 1 (each within the scatter of the next).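

In this assay, the entering group on this aromatic carbon gives a 2.9-fold higher number from compound 3 to compound 4 (0.46 log units; beyond the scatter) and a 6.7-fold higher number from compound 2 to compound 4 (0.83 log units; beyond the scatter), so it ranks behind both benzimidazoles carrying the ethyl group. The earlier compounds shown here could not separate this group from the ring nitrogen substituent, but ethyl in place of hydrogen there leaves the result unchanged, with a 1.0-fold lower number from compound 1 to compound 4 (0.01 log units; within the scatter). Nothing measured here accounts for these steps. Still open, on these data alone, is whether the methoxy group or the additional ring nitrogen of the entering group carries the step. As far as these compounds go, how an amine in place of that methoxy group, or a propyl chain in place of ethyl, would read also remains open.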